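The source may report more compounds than this note shows. Statements on the series, on what has been measured and on what is new or still open speak of the compounds shown alone.

Measured in an assay on isolated protein for inhibition of solute carrier family 22 member 12 (Homo sapiens), tested at 3 uM; a higher number here means more inhibition at the concentration tested (going by the name of the read-out), a lower number less inhibition:
compound 1, `CCCc1cc(C(=O)N2CC=CC2)cc(C(F)(F)F)c1O`: 49%
compound 2, `N#Cc1cc(C(=O)N2CC=CC2)cc(C(F)(F)F)c1O`: 83%
compound 3, `N#Cc1cc(C(=O)N2CC=CC2)cc(Cl)c1O`: 66%

Compound 3 stands second highest of the three numbers in this assay; its gap to compound 1 and its gap to compound 2 are both beyond the scatter. The two measured steps are a number 34 percentage points higher from compound 1 to compound 2 (beyond the scatter) and a number 17 percentage points lower from compound 2 to compound 3 (beyond the scatter).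

Compound 4 is `CC(C)(C)c1cc(C(=O)N2CC=CC2)cc(C#N)c1O`. It follows from compound 3 by one change: tert-butyl in place of chloro on an aromatic carbon. Among the measured compounds shown here, only one measured step alters the group at this position, a number 17 percentage points lower from compound 2 to compound 3 (beyond the scatter), and it was modest. The other step, a number 34 percentage points higher from compound 1 to compound 2 (beyond the scatter), concerns a different position and a different pair of groups, so it says nothing about a tert-butyl. For the measured compounds named here, no measured compound carries a tert-butyl anywhere, so the direction of the change is open on the present numbers. Going by the values given here, since the single step at this position was modest, the expected step is a number 6 percentage points lower from compound 3 to compound 4 (within the scatter), which is within the scatter, and the estimate for compound 4 in this assay is 60%, with a range from 38% to 82% that allows for either direction.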

Compound 4, a percentage reported as inhibition, at one concentration (the size of the read-out at that concentration, not a potency): 92%
The estimate for compound 4 lay 32 percentage points below the measured number; the measured number lies above the stated range.
By their numbers in this assay, from the lowest: compound 1; then compound 3; then compounds 2 and 4 (each within the scatter of the next).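

Exchanging chloro for tert-butyl, ortho to a hydroxy group and meta to a cyano group, gives a number 26 percentage points higher from compound 3 to compound 4 (beyond the scatter) in this assay, so this position accepts a tert-butyl and the earlier drop on going to chloro is not a general penalty for change here. With the cyano group held fixed, replacing trifluoromethyl with tert-butyl gives a number 9 percentage points higher from compound 2 to compound 4 (within the scatter), which leaves these two groups indistinguishable in this read-out, while chloro is the only one of the three set apart from both. The compounds shown offer no independent measurement that could explain this ranking.

Open, going by these compounds, is whether the tert-butyl result carries over when propyl replaces the cyano group, and whether an amine, a carboxylic acid or a longer chain at this position would read with tert-butyl and trifluoromethyl or with chloro. On these data alone, the amide part of the shared core is also unchanged throughout, so the effect of replacing it with, for example, a piperidine amide remains unknown, and these single-concentration numbers give no potency.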